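Methoxy in Place of Chloro on the Shared Core

A few compounds are considered here, and "the series" means these few. Any claim that something is new, unique, unknown or untested is made for them only; others in the source may bear on it.

Two compounds have so far been tested in a functional assay on Ehrlich cells (Mus musculus) for cytotoxicity, read by trypan blue exclusion, with a stated time of 2 h, tested at 5 ug/mL; on this read-out higher numbers stand for a weaker effect at the one concentration tested and lower numbers for a stronger effect:
compound 1 `CNc1c(C#N)[n+]([O-])c2cc(Cl)ccc2[n+]1[O-]` gives 96%
compound 2 `Cc1c(C(=O)N=[N+]=[N-])[n+]([O-])c2cc(Cl)ccc2[n+]1[O-]` gives 98%

Compound 2 holds the higher of the two numbers, yet its nearest neighbour, compound 1, sits within the usual scatter, so the two cannot be told apart. Compound 3 `COc1ccc2c(c1)[n+]([O-])c(C(=O)N=[N+]=[N-])c(C)[n+]2[O-]` differs from compound 2 by methoxy in place of chloro on an aromatic carbon. Going by the values given here, no measured pair shows what such a change does here, so in this assay the step from compound 2 to compound 3 is expected to be small or none beyond the scatter. Compound 3 is therefore expected to give 95%, within 85% to 100%, an expected step of a number 3 percentage points lower from compound 2 to compound 3 (within the scatter).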

Compound 3, a percentage reported as activity, at one concentration (the size of the read-out at that concentration, not a potency): 99%
The estimate for compound 3 lay 4 percentage points below the measured number; measured number inside the range.
By their numbers in this assay, from the lowest: compounds 1, 2 and 3 (each within the scatter of the next).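

Going by these compounds alone, this is the first measured pair for this change. In this assay, methoxy in place of chloro on this aromatic carbon leaves compound 2 and compound 3 indistinguishable (a number 1 percentage points higher from compound 2 to compound 3 (within the scatter)), so at this position of the shared core, the exchange makes no readable difference at the one concentration tested. Nothing available explains this result.

Going by these compounds, whether an amine or a longer chain such as ethoxy on the same carbon would give a clearly different number remains open. So does whether methoxy would behave the same way alongside the other substituents of compound 1.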